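Methoxy for hydrogen on the fused ring of compound 3

The source may report more compounds than this note shows. Statements on the series, on what has been measured and on what is new or still open speak of the compounds shown alone.

Measured compounds in a functional assay on PC-3 cells (Homo sapiens) for inhibition; on this read-out lower numbers stand for stronger inhibition and higher numbers for weaker inhibition: compound 1 `CCn1c(=O)/c(=C2\Sc3ccc(C)cc3N2C)s/c1=C\c1ccncc1Nc1ccccc1Cl` gives 500 nM; compound 2 `CCn1c(=O)/c(=C2\Sc3ccc(OC)cc3N2C)s/c1=C\c1ccncc1Nc1ccccc1C` gives 370 nM; compound 3 `CCn1c(=O)/c(=C2\Sc3ccccc3N2C)s/c1=C\c1ccncc1Nc1ccccc1Cl` gives 780 nM.

Compound 3 has the highest number of the three; the gap to compound 1 lies within the scatter, the gap to compound 2 beyond it. Compound 4 `CCn1c(=O)/c(=C2\Sc3ccc(OC)cc3N2C)s/c1=C\c1ccncc1Nc1ccccc1Cl` differs from compound 3 by methoxy in place of hydrogen on an aromatic carbon. Among the compounds with values here, the only single-place step at this position is a 1.6-fold higher number from compound 1 to compound 3 (0.19 log units; within the scatter), so the position tolerates a small group without a change beyond the scatter. Compound 2 carries the same methoxy but also a different aniline substituent, so it bears only loosely. The expected step is a 1.6-fold lower number from compound 3 to compound 4 (0.19 log units; within the scatter), small and within the scatter. Compound 4 is therefore estimated at 500 nM, range 220 nM to 1100 nM.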

Compound 4, half-maximal inhibitory concentration: 760 nM
The estimate for compound 4 lay 1.5-fold (0.18 log units) below the measured number; measured number inside the range.
By their numbers in this assay, from the lowest: compounds 2, 1, 4 and 3 (each within the scatter of the next, the first and the last beyond it).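

In this assay, methoxy in place of hydrogen on the fused ring stays within the scatter (a 1.0-fold lower number from compound 3 to compound 4 (0.01 log units; within the scatter)), and so does methoxy in place of methyl (a 1.5-fold higher number from compound 1 to compound 4 (0.18 log units; within the scatter)), so hydrogen, methyl and methoxy cannot be told apart here with chloro held on the other aromatic ring. Within the data shown here, the one single-place step beyond the scatter lies away from this position, at chloro in place of methyl (a 2.1-fold higher number from compound 2 to compound 4 (0.31 log units; beyond the scatter)), and it is modest. Nothing available explains these steps.

From the compounds shown here alone, whether an amine, a carboxylic acid or a longer chain at the fused-ring position would also stay within the scatter remains open. Also open, going by these compounds, is whether the chloro-for-methyl step holds with hydrogen or methyl on the fused ring.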